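This account rests on a few compounds, and the source may have more. Where it says the series, first, only, none or still open, it means among the compounds named here.

Compound 1 `COc1cc(-c2c(C)nc3c(N4CC[C@@H](NC(C)=O)C4)cc(C)nn23)ccc1F`: > 95%
Compound 2 `COc1ccc(-c2c(C)nc3c(N4CC[C@@H](NC(=O)OC5CCCCC5)C4)cc(C)nn23)cc1OC`: > 95%

In an ADME assay on microsomes from liver (Mus musculus) for metabolic stability, read by LC-MS, with NADPH named in the record, with a stated time of 60 min, tested at 1 uM, in the absence of a further agent (a higher number here means that more of the compound is left, a lower number that less of the compound is left), compound 2 gives > 95%, and this is a limit of the assay rather than a number. Both values shown sit at that limit (the limit of > 95% in this assay, at which 2 of the 2 values shown sit), so compound 2 cannot be placed higher or lower than compound 1. Compound 3 `COc1ccc(-c2c(C)nc3c(N4CC[C@@H](SC(C)=O)C4)cc(C)nn23)cc1OC` has not been measured; it differs from compound 2 by acetylsulfanyl in place of (cyclohexyloxycarbonyl)amino on a saturated ring carbon. Among the measured compounds shown here, no step between measured compounds is available, so the size of this change cannot be read from them. The step of a number at least 13 percentage points lower from compound 2 to compound 3 (beyond the scatter) is expected to be a modest drop, not clearly beyond the usual scatter. Compound 3 is estimated at 82%, with a range from 50% to 95%.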

Compound 3, percent of the compound remaining: > 95%
Compound 3: no number, only a limit (the forecaster's own chance of this, stated with the estimate: 40%); middle value at least 13 percentage points from the limit.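

No step can be read from compound 2 to compound 3, because both results are limits of the assay, not numbers: the limit of > 95% in this assay, at which 3 of the 3 values shown sit.

The compounds shown leave open whether acetylsulfanyl in place of (cyclohexyloxycarbonyl)amino changes the amount of compound remaining in this assay.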